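Half-life notes: 4-carboxyphenyl to azepan-1-yl

The source may report more compounds than this note shows. Statements on the series, on what has been measured and on what is new or still open speak of the compounds shown alone.

Within the data shown here, the series offers only one exact number so far. Compound 1 `Cc1nc2ccc(Cl)cn2c1C(=O)NCc1ccc(-c2ccccc2)cc1` reaches only a limit (> 1 h) in an ADME assay (liver, Mus musculus) for metabolic stability, using microsomes; a lower number here means that the compound disappears faster, a higher number that the compound lasts longer. Compound 2 `CCc1nc2ccc(Cl)cn2c1C(=O)NCc1ccc(-c2ccccc2Cl)cc1` gives a measured half-life of 0.218 h in this assay. Compound 3 `CCc1nc2cc(Cl)ccn2c1C(=O)NCc1ccc(-c2ccc(C(=O)O)cc2)cc1` also stands at a limit (> 2 h) and so has no exact half-life.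

From compound 3 to compound 4 `CCc1nc2cc(Cl)ccn2c1C(=O)NCc1ccc(N2CCCCCC2)cc1`, azepan-1-yl replaces 4-carboxyphenyl on an aromatic carbon, para to a large group (azepan-1-yl in place of 4-carboxyphenyl on an aromatic carbon).

Among the measured compounds shown here, no measured pair differs in one place, so the size of this step is poorly constrained. For the measured compounds named here, compound 3 is the only measured compound carrying 4-carboxyphenyl, while compound 2, which lacks that group, gives 0.218 h as its half-life. Compound 1 goes against this reading: it also lacks the group and still reports a limit. A shorter half-life, beyond the usual scatter, is therefore expected, with an estimated step of an at least 5.0-fold lower number from compound 3 to compound 4 (0.69 log units; beyond the scatter) in this assay. For compound 4 the estimated half-life is 0.4 h, with an expected range of 0.12 h to 1.2 h.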

Compound 4, half-life: 0.0317 h
The estimate for compound 4 lay 13-fold (1.10 log units) above the measured number; measured number below the stated range.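

In this assay, among these compounds, replacing 4-carboxyphenyl with azepan-1-yl gives the first step between compounds that differ in one place: an at least 63-fold lower number from compound 3 to compound 4 (1.79 log units; beyond the scatter). The group on this aromatic carbon, para to a large group, can therefore move the half-life well beyond the usual scatter, and with azepan-1-yl in place compound 4 gives 0.0317 h as an exact value. The printed step gives only the smallest possible size of the change, because compound 3 stands at a limit and has no exact half-life: the limit of > 2 h in this assay, at which 1 of the 4 values shown sits.

The step exchanges a six-membered aromatic ring of carbon bearing a carboxylic acid for a seven-membered non-aromatic ring with one hetero atom, so the compounds shown do not separate the loss of the carboxylic acid from the entry of azepan-1-yl. On these data alone, whether the short half-life belongs to azepan-1-yl in particular or extends to other saturated amines such as piperidin-1-yl or morpholin-4-yl, and whether a phenyl carrying a primary amide instead of the carboxylic acid holds the half-life of compound 3, stays open on this core.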